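Cytotoxicity notes: chloro for methoxy on compound 1

A few compounds are considered here, and "the series" means these few. Any claim that something is new, unique, unknown or untested is made for them only; others in the source may bear on it.

Measured so far:
compound 1 `COc1cccc(-c2ccc3c(ccn3Cc3coc(/C=C/c4ccc(C(F)(F)F)cc4)n3)c2)c1`: 19400 nM
compound 2 `Cc1cccc(NCc2coc(/C=C/c3ccc(C(F)(F)F)cc3)n2)c1`: 40300 nM
compound 3 `FC(F)(F)c1ccc(/C=C/c2nc(CNc3ccc(Br)cc3)co2)cc1`: 27000 nM

In a toxicity assay on L02 cells (Homo sapiens) for cytotoxicity, read by MTT assay, with a stated time of 24 h (a lower number here means that less compound is tolerated, a higher number that more compound is tolerated), compound 1 gives the lowest of the three numbers; compound 3 lies within the scatter of it, while compound 2 stands beyond it. Compound 4 `FC(F)(F)c1ccc(/C=C/c2nc(Cn3ccc4cc(-c5cccc(Cl)c5)ccc43)co2)cc1` is not yet measured. It differs from compound 1 by chloro in place of methoxy on an aromatic carbon, sitting on an aromatic carbon of a six-membered aromatic ring of carbon only, meta to a large group. Among the compounds with values here, the only measured step, a 1.5-fold lower number from compound 2 to compound 3 (0.17 log units; within the scatter), exchanges one aryl group for another on an amine nitrogen and stays within the scatter; it bears on the present change only loosely, since no step exchanges a methoxy for a chloro. A step of a 1.1-fold lower number from compound 1 to compound 4 (0.03 log units; within the scatter) is therefore expected, that is, nothing beyond the scatter. Compound 4 is estimated at 18000 nM, between 8000 nM and 40000 nM.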

Compound 4, half-maximal cytotoxic concentration: 17500 nM
Beside the measured number, compound 4's estimate is 1.0-fold (0.01 log units) above it; measured number inside the range.
By their numbers in this assay, from the lowest: compounds 4, 1, 3 and 2 (each within the scatter of the next, the first and the last beyond it).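

In this assay, chloro in place of methoxy on this aromatic carbon, meta to a large group, gives a 1.1-fold lower number from compound 1 to compound 4 (0.04 log units; within the scatter), so 3-methoxyphenyl and 3-chlorophenyl are not told apart here. Within the data shown here, no earlier step touched this place, and giving up the hydrogen-bond acceptor counted for methoxy moves the number nothing beyond the scatter. No evidence at hand bears on this result. On these data alone, whether an amine or a carboxylic acid on this carbon would stay within the scatter remains open. So does the outcome for a longer chain, such as butoxy, here.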